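The source may report more compounds than this note shows. Statements on the series, on what has been measured and on what is new or still open speak of the compounds shown alone.

Of the compounds shown here, two have so far been measured for agonist activity. Compound 1 `CCCCCCCCCCCOc1ccccc1CCC(=O)OCCCOP(=O)(O)OC[C@H](N)C(=O)O` gives 14.6% in an assay on cells for agonist activity at probable G-protein coupled receptor 34 (Mus musculus), with a stated time of 1 h (a lower number here means a smaller maximal response, a higher number a larger maximal response), a low maximal response. Compound 2 `N[C@@H](COP(=O)(O)OCCCOC(=O)CCc1ccccc1OCc1cccc(OC2CCCCC2)c1)C(=O)O` gives 18.8% in this assay. On the numbers shown, compound 2 sits alongside compound 1: the two values lie within the usual scatter of each other, so neither can be set above the other with confidence, and both point to a small maximal response.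

The next compound, compound 3 `N[C@@H](COP(=O)(O)OCCCOC(=O)CCc1ccccc1OCc1cccc(Oc2ccc(Cl)cc2)c1)C(=O)O`, keeps the whole of compound 2 except for one change at the outer end of the molecule: 4-chlorophenyl in place of cyclohexyl on an oxygen on an aromatic ring. For the measured compounds named here, no measured pair shows what this kind of exchange does in this assay, so the size of the step rests on expectation alone. Both measured compounds give small responses, and nothing here suggests the exchange will move the number far; the step from compound 2 to compound 3 is expected to be a number 0.8 percentage points lower from compound 2 to compound 3 (within the scatter), a change not beyond the scatter. Compound 3 is therefore expected to give about 18%, within a range from 8% to 32%.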

Compound 3, largest response reached (Emax), in percent of the reference or control that the assay uses: 17.8%
The estimate for compound 3 lay 0.2 percentage points above the measured number; low and high end bracket the measured number.
By their numbers in this assay, from the lowest: compounds 1, 3 and 2 (each within the scatter of the next).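

In this assay, for the compounds shown here, the exchange of cyclohexyl for 4-chlorophenyl on an oxygen on an aromatic ring gives a number 1 percentage points lower from compound 2 to compound 3 (within the scatter), and this is the first measured pair that differs at this place alone. The two compounds cannot be told apart: a six-membered non-aromatic ring of carbon only and a six-membered aromatic ring carrying chlorine give the same small maximal response within the scatter, so this one exchange does not show the outer ring type to matter for the read-out. No data on hand account for this match, so the result stands as an observation without an explanation.

As far as these compounds go, whether any group at this place can raise the maximal response remains open, since one exchange between two ring groups says nothing about an amine, a carboxylic acid or a longer chain there. From the compounds shown here alone, it is equally open whether a change elsewhere on the shared core, or a fluorine in place of the chlorine on the aromatic ring, would give a response clearly beyond the scatter.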